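The source may report more compounds than this note shows. Statements on the series, on what has been measured and on what is new or still open speak of the compounds shown alone.

Three compounds have numbers in an in vitro assay on BHK cells for displacement of a labelled ligand from gastric inhibitory polypeptide receptor (Homo sapiens), read by scintillation proximity assay; a higher number here means a weaker inhibitor, a lower number a stronger inhibitor. Compound 1 `O=C(O)CCNC(=O)c1ccc(CC(c2ccc(Cl)cc2)c2nc(-c3ccc(C(F)(F)F)cc3)cs2)cc1` gives 381 nM in this assay. Compound 2 `O=C(O)CCNC(=O)c1ccc(CN(c2ccc(Cl)cc2)c2nc(-c3ccc(C(F)(F)F)cc3)cs2)cc1` gives 649 nM, the second highest of the three numbers. Compound 3 `O=C(O)CCNC(=O)c1ccc(CN(c2ccc(C3=CCCCC3)cc2)c2nc(-c3ccc(Cl)cc3)c(-c3ccccc3)s2)cc1` gives 1000 nM. The number for compound 2 lies within the usual scatter of both the number for compound 1 and the number for compound 3, so no order among the three can be read from these measurements.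

Compound 4 `Cc1cc(N(Cc2ccc(C(=O)NCCC(=O)O)cc2)c2nc(-c3ccc(C(F)(F)F)cc3)cs2)ccc1C(C)C` differs from compound 2 in one place: 4-isopropyl-3-methylphenyl in place of 4-chlorophenyl on a nitrogen on an aromatic ring. In words, 4-isopropyl-3-methylphenyl in place of 4-chlorophenyl on a nitrogen on an aromatic ring. Among the measured compounds shown here, no measured pair shows this change, so the data give no size for it. For the measured compounds named here, since the three numbers so far sit close together, the expected step from compound 2 to compound 4, a 1.2-fold higher number from compound 2 to compound 4 (0.06 log units; within the scatter), is one that stays within the scatter, leaning if anything towards a slightly higher number. Compound 4 is therefore estimated at 750 nM in this assay, with a range from 250 nM to 2200 nM.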

Compound 4, half-maximal inhibitory concentration: 633 nM
Beside the measured number, compound 4's estimate is 1.2-fold (0.07 log units) above it; the measured number falls inside the stated range.
By their numbers in this assay, from the lowest: compounds 1, 4, 2 and 3 (each within the scatter of the next, the first and the last beyond it).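

In this assay, among the compounds shown here, the pair gives the first single-place step (a 1.0-fold lower number from compound 2 to compound 4 (0.01 log units; within the scatter)), and that step lies within the scatter. At this place, on a nitrogen on an aromatic ring, a 4-isopropyl-3-methylphenyl group of 10 heavy atoms, all carbon, thus reads the same as a 4-chlorophenyl group of 7 heavy atoms, so the chlorine is not needed for a number of this size in this pair. No measurement shown gives any explanation for this match between the two groups.

The compounds shown leave open how a group other than a substituted phenyl would read at this place, such as a saturated cyclohexyl ring, or a phenyl ring carrying an amine or a carboxylic acid. They also leave open whether 4-isopropyl-3-methylphenyl would read the same on the core of compound 1.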